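Working notes: benzyl for phenyl on the five-membered ring

A few compounds are considered here, and "the series" means these few. Any claim that something is new, unique, unknown or untested is made for them only; others in the source may bear on it.

Measured so far:
compound 1 `Cc1ccc(C(=O)CCc2nnc(-c3ccccc3)o2)cc1` — 33.3%
compound 2 `Cc1ccc(C(=O)CCc2nnc(-c3ccc([N+](=O)[O-])cc3)o2)cc1` — 52%

In a functional assay on the whole organism (strain Wistar) for inhibition, with Rattus norvegicus as the target, with stated times of 30 min and 2 h, at a dose of 20 mg/kg by the oral route (a lower number here means less inhibition, a higher number more inhibition at the dose given (going by the name of the read-out)), compound 1 gives 33.3%, the lower of the two numbers; compound 2 gives 52%. For the measured compounds named here, the one measured step, a number 18.7 percentage points higher from compound 1 to compound 2 (beyond the scatter), concerns a different site and does not bear on the change considered here. Compound 3 `Cc1ccc(C(=O)CCc2nnc(Cc3ccccc3)o2)cc1` differs from compound 1 by benzyl in place of phenyl on an aromatic carbon. Going by the values given here, no measured step covers this change, so no step beyond the scatter is expected: a number 0.3 percentage points lower from compound 1 to compound 3 (within the scatter). Compound 3 is therefore estimated at 33%, with a range from 15% to 50%.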

Compound 3, a percentage reported as inhibition, in the whole organism at one dose (the size of the read-out at that dose, not a potency): 24.7%
Beside the measured number, compound 3's estimate is 8.3 percentage points above it; low and high end bracket the measured number.
By their numbers in this assay, from the lowest: compounds 3 and 1 (each within the scatter of the next); then compound 2.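

Moving from phenyl to benzyl on the five-membered ring gives a number 8.6 percentage points lower from compound 1 to compound 3 (within the scatter) in this assay, so this read-out does not separate the two groups at this place. The aromatic ring therefore need not be bonded directly to the five-membered ring for the inhibition seen with compound 1 to remain within the scatter. No available data explain this result.

From the compounds shown here alone, whether nitro on the benzyl ring would give a step like a number 18.7 percentage points higher from compound 1 to compound 2 (beyond the scatter) remains open. So does the outcome with a longer chain, such as phenethyl, or with an amine at this place.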